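A few compounds are considered here, and "the series" means these few. Any claim that something is new, unique, unknown or untested is made for them only; others in the source may bear on it.

In an assay on HEK293 cells for positive allosteric modulation of metabotropic glutamate receptor 5 (Homo sapiens), read by FLIPR, with a stated time of 1 h (on this read-out lower numbers stand for an effect already at smaller amounts and higher numbers for an effect only at larger amounts of compound), compound 1 `O=C(C1CCCCC1)N1CCc2nc(C#Cc3ccccc3)sc2C1` gives 167 nM and compound 2 `O=C(C1CCOCC1)N1CCc2nc(C#Cc3ccccc3)sc2C1` gives 290 nM; the step of a 1.7-fold higher number from compound 1 to compound 2 (0.24 log units; within the scatter) leaves the two inside the scatter, so on the numbers shown compound 2 is not separated from compound 1. Compound 3 `O=C(c1cccc(Cl)c1)N1CCc2nc(C#Cc3ccccc3)sc2C1` differs from compound 2 by 3-chlorophenyl in place of oxan-4-yl on a carbonyl carbon. Going by the values given here, the only measured step swaps one saturated six-membered ring for another and says little about an aromatic ring entering at the carbonyl carbon, so the expected step in this assay a 1.9-fold lower number from compound 2 to compound 3 (0.29 log units; within the scatter) is uncertain, with a modest move to a lower number thought slightly more likely. Compound 3 is estimated at 150 nM, between 40 nM and 600 nM.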

Compound 3, half-maximal effective concentration: 8.7 nM
Beside the measured number, compound 3's estimate is 17-fold (1.24 log units) above it, outside the stated range (below it).
By their numbers in this assay, from the lowest: compound 3; then compounds 1 and 2 (each within the scatter of the next).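

In this assay 3-chlorophenyl on the carbonyl carbon in place of oxan-4-yl gives a 33-fold lower number from compound 2 to compound 3 (1.52 log units; beyond the scatter) and in place of cyclohexyl gives a 19-fold lower number from compound 1 to compound 3 (1.28 log units; beyond the scatter) so both steps lie beyond the scatter. The exchange of one saturated ring for the other did not separate compounds, whereas this position does respond to an aromatic ring carrying chlorine. Nothing measured on these groups bears on this result. As far as these compounds go, how much of the step belongs to the ring and how much to the chlorine remains open, and a plain phenyl would divide the two. An amine or a carboxylic acid on that ring also remains an open case.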